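Methylation of the aryl hydroxy group in the pyrazole urea series

The source may report more compounds than this note shows. Statements on the series, on what has been measured and on what is new or still open speak of the compounds shown alone.

Two members of the series have a number in a functional assay on CCRF-CEM cells (Homo sapiens) for inhibition, read by sulforhodamine B assay, with a stated time of 48 h, tested at 10 uM (on this read-out lower numbers stand for a stronger effect and higher numbers for a weaker effect at the one concentration tested), so far. Compound 1 `COc1cc(Cl)cc(-c2nn(-c3cccc(NC(=O)Nc4cccc(C(F)(F)F)c4)c3)cc2-c2ccncc2)c1` gives 3.34% in this assay. Compound 2 `O=C(Nc1cccc(-n2cc(-c3ccncc3)c(-c3cc(O)cc(Cl)c3)n2)c1)Nc1ccc(Cl)c(Cl)c1` gives 4.11% in this assay, a number that lies within the usual scatter of the value of compound 1, so the two compounds cannot be told apart on this read-out; both leave only a small fraction of the read-out standing at the single concentration tested.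

Compound 3 `COc1cc(Cl)cc(-c2nn(-c3cccc(NC(=O)Nc4ccc(Cl)c(Cl)c4)c3)cc2-c2ccncc2)c1` is the next member to be measured in this assay. Against compound 2 the change is methyl in place of hydrogen on an oxygen on an aromatic ring, that is, hydroxy to methoxy on the 3-chloro-5-hydroxyphenyl ring, giving 3-chloro-5-methoxyphenyl. Among the compounds with values here, no pair of measured compounds shows this change on its own. Compound 1 already carries the methoxy group, on a different urea partner, and its value sits beside that of compound 2, so no step beyond the scatter is expected from compound 2 to compound 3 in this assay, in either direction. The expected step is a number 0.1 percentage points lower from compound 2 to compound 3 (within the scatter). Compound 3 is therefore estimated at 4%, with a range from 1% to 12%.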

Compound 3, a percentage reported as activity, at one concentration (the size of the read-out at that concentration, not a potency): 5.73%
For compound 3 the middle estimate is 1.7 percentage points below the measured one; the measured number falls inside the stated range.
By their numbers in this assay, from the lowest: compounds 1, 2 and 3 (each within the scatter of the next).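

In this assay the change from hydroxy to methoxy on the 3-chloro-5-hydroxyphenyl ring can now be read on its own, with the 3,4-dichlorophenyl urea partner held fixed: methyl in place of hydrogen on this oxygen gives a number 1.6 percentage points higher from compound 2 to compound 3 (within the scatter) and so does not separate the two compounds on this read-out. With the 3-chloro-5-methoxyphenyl ring held fixed, 3,4-dichlorophenyl in place of 3-(trifluoromethyl)phenyl on the amide-type nitrogen can also be read alone, as a number 2.4 percentage points higher from compound 1 to compound 3 (within the scatter), and this change does not separate its two compounds either. No supporting data bear on what lies behind these two steps.

The compounds shown leave open how this oxygen would read with a longer chain on it, such as ethyl or a 2-aminoethyl chain, and how the ring would read with the oxygen replaced by a fluorine atom. All three values come from a single concentration, so any difference in potency among these compounds remains open, and a full concentration series would be needed to address it.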